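Phenethyl for 3-fluorophenyl on a sulfur

This account rests on a few compounds, and the source may have more. Where it says the series, first, only, none or still open, it means among the compounds named here.

In a functional assay on HeLa cells (Homo sapiens) for inhibition, read by CCK-8 assay, with a stated time of 72 h, tested at 2 uM (on this read-out lower numbers stand for less inhibition of growth and higher numbers for more inhibition of growth at the one concentration tested), compound 1 (`Nc1ccccc1NC(=O)/C=C/c1ccc(CSc2cccc(F)c2)cc1`) gives 2.25% and so sits within the usual scatter of compound 3 (`Nc1ccccc1NC(=O)c1ccc(CSc2ccc(C(F)(F)F)cn2)cc1`) at 11.5% and clearly under compound 2 (`Cc1ccc(SCc2ccc(C(=O)Nc3ccccc3N)cc2)cc1`) at 33.8% in the same measurement.

Compound 4 (`Nc1ccccc1NC(=O)/C=C/c1ccc(CSCCc2ccccc2)cc1`) keeps the core of compound 1 and changes one group, with phenethyl in place of 3-fluorophenyl on a sulfur. For the measured compounds named here, no measured pair of compounds shows this swap on its own, so the forecast is uncertain. In this assay only a small rise is expected (a number 5.8 percentage points higher from compound 1 to compound 4 (within the scatter)), one that would stay within the scatter. Compound 4 is expected to give 8% (estimated range 0% to 28%).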

Compound 4, percent growth inhibition at one concentration: 0.19%
Beside the measured number, compound 4's estimate is 7.8 percentage points above it; measured number inside the range.
By their numbers in this assay, from the lowest: compounds 4, 1 and 3 (each within the scatter of the next, the first and the last beyond it); then compound 2.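

In this assay, putting phenethyl in place of 3-fluorophenyl on a sulfur gives a number 2.1 percentage points lower from compound 1 to compound 4 (within the scatter) and so makes no readable difference. For the compounds shown here, this is the first pair to isolate this position, and on the core of compound 1 a ring held directly on the sulfur and one held through the phenethyl chain read alike. No measurement shown explains this result.

As far as these compounds go, it remains open whether the same swap would read alike on the core of compound 2. From the compounds shown here alone, it is also open whether a group carrying an amine or a carboxylic acid on this sulfur would move the number.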